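This account rests on a few compounds, and the source may have more. Where it says the series, first, only, none or still open, it means among the compounds named here.

Measured in a functional assay (aorta) for inhibition, with Oryctolagus cuniculus as the target; on this read-out higher numbers stand for weaker inhibition and lower numbers for stronger inhibition:
- Compound 1 `CC1=NC(=S)N(C(=O)OC2CCN(Cc3ccccc3)CC2)C(c2cccc([N+](=O)[O-])c2)/C1=C(\O)OC(C)C`: 4 nM
- Compound 2 `CC1=C(C(=O)OC(C)C)C(c2ccccc2C(F)(F)F)N(C(=O)OC2CCN(Cc3ccccc3)CC2)C(=O)N1`: 50 nM
- Compound 3 `CC1=C(C(=O)OC(C)C)C(c2ccccc2[N+](=O)[O-])N(C(=O)OC2CCN(Cc3ccccc3)CC2)C(=O)N1`: 8 nM

Compound 3 lies within the scatter of compound 1 and well under compound 2. Next is compound 4 `CC1=C(C(=O)OC(C)C)C(c2cccc([N+](=O)[O-])c2)N(C(=O)OC2CCN(Cc3ccccc3)CC2)C(=O)N1`, with this change from compound 3: 3-nitrophenyl in place of 2-nitrophenyl on a saturated ring carbon. In words, 3-nitrophenyl replaces 2-nitrophenyl on a saturated ring carbon.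

Among the compounds with values here, no measured step covers this exchange. The nearest is a 6.3-fold lower number from compound 2 to compound 3 (0.80 log units; beyond the scatter), a modest step that shows the aryl group can matter. Compound 1, which carries 3-nitrophenyl on its own core, gives 4 nM, within the scatter of compound 3. No step beyond the scatter is therefore expected in this assay.

The expected step is a 1.3-fold lower number from compound 3 to compound 4 (0.12 log units; within the scatter).

Compound 4 is estimated at 6 nM, with an expected range of 2 nM to 20 nM.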

Compound 4, half-maximal inhibitory concentration: 12 nM
Compound 4: middle estimate off by 2.0-fold (0.30 log units), on the low side; the range from low to high includes it.
By their numbers in this assay, from the lowest: compounds 1, 3 and 4 (each within the scatter of the next, the first and the last beyond it); then compound 2.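

In this assay, 3-nitrophenyl and 2-nitrophenyl on this saturated ring carbon cannot be told apart (a 1.5-fold higher number from compound 3 to compound 4 (0.18 log units; within the scatter)), so on the shared core this exchange gives no readable change. The separation from 2-(trifluoromethyl)phenyl also holds with 3-nitrophenyl (a 4.2-fold lower number from compound 2 to compound 4 (0.62 log units; beyond the scatter)), so it does not depend on 2-nitrophenyl alone. Nothing available bears on the reason for either step. Still open, as far as these compounds go, is whether the value holds with unsubstituted phenyl, or with an amine or a carboxylic acid in place of the nitro group on this ring.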